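Swapping the Nitrophenyl Arm of an Antiproliferative Series

A few compounds are considered here, and "the series" means these few. Any claim that something is new, unique, unknown or untested is made for them only; others in the source may bear on it.

Compound 1 `COc1cc(C2=NN(C(C)=O)C(c3ccc([N+](=O)[O-])cc3)O2)cc(OC)c1OC` gives 4200 nM in a functional assay on L1210 cells (Mus musculus) for antiproliferative activity, read by MTT assay, with a stated time of 72 h; on this read-out higher numbers stand for weaker inhibition and lower numbers for stronger inhibition.
Compound 2 `COc1cc(C2=NN(C(C)=O)C(c3cccc([N+](=O)[O-])c3)O2)cc(OC)c1OC` gives 39000 nM in this assay.
Compound 3 `COc1ccccc1C1OC(c2cc(OC)c(OC)c(OC)c2)=NN1C(C)=O` gives 48000 nM in this assay.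

Compound 1 stands lowest of the three numbers, and both exchanges of its 4-nitrophenyl group have weakened inhibition: the step of a 9.3-fold higher number from compound 1 to compound 2 (0.97 log units; beyond the scatter) and the step of an 11-fold higher number from compound 1 to compound 3 (1.06 log units; beyond the scatter). Compound 4 `COc1cc(OC)cc(C2OC(c3cc(OC)c(OC)c(OC)c3)=NN2C(C)=O)c1` makes a third exchange at the same place, (3,5-dimethoxyphenyl in place of 4-nitrophenyl on a saturated ring carbon). The two measured exchanges point the same way, so compound 4 is expected to follow them, with a step of a 7.1-fold higher number from compound 1 to compound 4 (0.85 log units; beyond the scatter) toward weaker inhibition. Compound 4 is therefore estimated at 30000 nM, with a likely range from 8000 nM to 100000 nM.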

Compound 4, half-maximal inhibitory concentration: 5900 nM
For compound 4 the middle estimate is 5.1-fold (0.71 log units) above the measured one; measured number outside the range, below it.
By their numbers in this assay, from the lowest: compounds 1 and 4 (each within the scatter of the next); then compounds 2 and 3 (each within the scatter of the next).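

At this saturated ring carbon, a nitro group is not needed for the lowest numbers in this assay: 3,5-dimethoxyphenyl matches 4-nitrophenyl, with a 1.4-fold higher number from compound 1 to compound 4 (0.15 log units; within the scatter). Methoxy-bearing aryl groups do not all behave alike, as 3,5-dimethoxyphenyl stands clear of 2-methoxyphenyl, with an 8.1-fold lower number from compound 3 to compound 4 (0.91 log units; beyond the scatter), and also of 3-nitrophenyl, with a 6.6-fold lower number from compound 2 to compound 4 (0.82 log units; beyond the scatter). Nothing available explains these differences. The compounds shown leave open how an aryl group carrying an amine or a carboxylic acid would fare at this carbon.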